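Aryl formamidine versus dicyanomethylene hydrazone on the shared core

A few compounds are considered here, and "the series" means these few. Any claim that something is new, unique, unknown or untested is made for them only; others in the source may bear on it.

Measured so far in a functional assay on HepG2 cells (Homo sapiens) for inhibition, read by MTT assay, with a stated time of 48 h; on this read-out lower numbers stand for stronger inhibition and higher numbers for weaker inhibition:
compound 1 `CCOC(=O)C1=C(N/C=N/c2nnc(S(N)(=O)=O)s2)Nc2[nH]nc(C)c2C1c1ccc(N(C)C)cc1` gives 38100 nM
compound 2 `CCOC(=O)C1=C(N/C=N/c2ccc([N+](=O)[O-])cc2)Nc2[nH]nc(C)c2C1c1ccc(N(C)C)cc1` gives 50900 nM
compound 3 `CCOC(=O)C1=C(NN=C(C#N)C#N)Nc2[nH]nc(C)c2C1c1ccc(N(C)C)cc1` gives 13700 nM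

Compound 3 holds the lowest number of the three in this assay; its nearest neighbour is compound 1 with a 2.8-fold lower number from compound 1 to compound 3 (0.44 log units; beyond the scatter) and the furthest compound 2 with a 3.7-fold lower number from compound 2 to compound 3 (0.57 log units; beyond the scatter). Compound 4 `CCOC(=O)C1=C(N/C=N/c2ccc(C)cc2)Nc2[nH]nc(C)c2C1c1ccc(N(C)C)cc1` carries the change (a group of 9 heavy atoms (8 carbon, 1 nitrogen; one six-membered aromatic ring of carbon only) in place of a group of 6 heavy atoms (3 carbon, 3 nitrogen; no ring), on an amine nitrogen), returning to an aryl formamidine of the kind seen in compound 1 and compound 2. Both reverse steps bear on it: a 2.8-fold lower number from compound 1 to compound 3 (0.44 log units; beyond the scatter) and a 3.7-fold lower number from compound 2 to compound 3 (0.57 log units; beyond the scatter), while the aryl swap a 1.3-fold higher number from compound 1 to compound 2 (0.13 log units; within the scatter) changed little. The expected step is therefore a 2.9-fold higher number from compound 3 to compound 4 (0.47 log units; beyond the scatter). Compound 4 is estimated in this assay at 40000 nM, with a range from 15000 nM to 110000 nM.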

Compound 4, half-maximal inhibitory concentration: 44400 nM
Compound 4: the middle estimate sits 1.1-fold (0.05 log units) below what was measured; the range from low to high includes it.
By their numbers in this assay, from the lowest: compound 3; then compounds 1, 4 and 2 (each within the scatter of the next).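

In this assay, the methyl for nitro swap (a 1.1-fold lower number from compound 2 to compound 4 (0.06 log units; within the scatter)) and the 4-methylphenyl for 5-sulfamoyl-1,3,4-thiadiazol-2-yl swap (a 1.2-fold higher number from compound 1 to compound 4 (0.07 log units; within the scatter)) leave the aryl formamidines of compound 1, compound 2 and compound 4 unresolved from one another. A third aryl group on the double-bonded nitrogen thus adds to the separation of the dicyanomethylene hydrazone (a 3.2-fold higher number from compound 3 to compound 4 (0.51 log units; beyond the scatter)). No supporting data explain this separation.

Open, on these data alone, is whether an amine or a carboxylic acid on the aromatic ring would move the formamidine number. Also open, as far as these compounds go, is whether the hydrazone keeps its number with an ethyl ester replacing one nitrile.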